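Oxygen-to-sulfur swap at the aryl ether of compound 1

The compounds below may be only part of what the source reports. "The series", "measured", "known", "first", "only" and "open" are said of these compounds alone.

The series is followed in a functional assay on MOLT-4 cells (Homo sapiens) for inhibition, read by sulforhodamine B assay, with a stated time of 48 h; on this read-out lower numbers stand for stronger inhibition of growth and higher numbers for weaker inhibition of growth. Compound 1 `Nc1cc(N)c2nc(-c3ccccc3)c(Oc3ccc(Cl)c(Cl)c3)nc2c1` gives 6310 nM in this assay, the lowest of the two numbers recorded so far. Compound 2 `COc1cc(CNc2nc3cc(N)cc(N)c3nc2-c2ccccc2)cc(OC)c1OC` gives 12300 nM in this assay; the gap between compound 1 and compound 2 lies within the scatter, so the two cannot be ordered on these data.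

The next compound is compound 3 `Nc1cc(N)c2nc(-c3ccccc3)c(Sc3ccc(Cl)c(Cl)c3)nc2c1`, which differs from compound 1 in one place: (3,4-dichlorophenyl)sulfanyl in place of 3,4-dichlorophenoxy on an aromatic carbon. Going by the values given here, no step between two measured compounds of this kind exists, so the size of this change has to be guessed from the structures alone. The group that leaves and the group that enters are of the same count of heavy atoms and the same count of donors and acceptors, and the change is confined to the single linking atom. The expectation is therefore a step from compound 1 to compound 3 of no clear direction, within the scatter, as a 1.0-fold lower number from compound 1 to compound 3 (0.00 log units; within the scatter). Compound 3 is estimated at 6300 nM in this assay, with a plausible range from 2500 nM to 16000 nM.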

Compound 3, concentration for 50% growth inhibition: 4070 nM
For compound 3 the middle estimate is 1.5-fold (0.19 log units) above the measured one; the measured number falls inside the stated range.
By their numbers in this assay, from the lowest: compounds 3, 1 and 2 (each within the scatter of the next, the first and the last beyond it).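

In this assay, going by these compounds alone, the exchange of 3,4-dichlorophenoxy for (3,4-dichlorophenyl)sulfanyl gives the first step that can be read: a 1.6-fold lower number from compound 1 to compound 3 (0.19 log units; within the scatter). At this aromatic carbon, next to the ring nitrogen and ortho to a phenyl group, the linking oxygen can therefore be exchanged for sulfur, with the dichlorinated ring and the rest of the core of compound 1 unchanged, without separating the two compounds on this read-out. No measured information in hand accounts for this result, so it stands as an observation on this single pair.

Open, going by these compounds, is how a sulfonyl or a methylene link in the same place would read in this assay, since one pair tells nothing about links other than oxygen and sulfur. Also open, on these data alone, is whether oxygen and sulfur would still give readings within the scatter of each other with an unsubstituted phenyl ring or a pyridine ring in place of the 3,4-dichlorophenyl ring.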